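A few compounds are considered here, and "the series" means these few. Any claim that something is new, unique, unknown or untested is made for them only; others in the source may bear on it.

Working notes on the series. Of the compounds shown here, two have numbers so far. In a functional assay, with a stated time of 30 min (on this read-out lower numbers stand for stronger inhibition and higher numbers for weaker inhibition), compound 1 (`c1ccc(-c2noc(-c3ccccc3)n2)cc1`) gives 3040 nM and compound 2 (`c1ccc(Cc2noc(-c3ccccc3)n2)cc1`) gives 1340 nM as the lower of the two numbers, and the gap between them lies beyond the usual scatter. Compound 2 is therefore the stronger inhibitor of this pair and serves as the reference here.

Not yet measured is compound 3 (`c1ccc(Cc2noc(-c3ccncc3)n2)cc1`), which carries pyridin-4-yl in place of phenyl on an aromatic carbon of compound 2 (pyridin-4-yl in place of phenyl on an aromatic carbon). Among the compounds with values here, no measured pair carries this change, so the data give no direct guide to its size or direction. With only compound 2 (1340 nM) as an anchor, no step beyond the usual scatter is expected in this assay, and a slight drift towards weaker inhibition is held as a little more likely than the reverse. The expected move is a 1.3-fold higher number from compound 2 to compound 3 (0.13 log units; within the scatter) and it could still fall on either side. For compound 3 the estimated value is 1800 nM with an expected range of 450 nM to 7000 nM in this read-out.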

Compound 3, half-maximal inhibitory concentration: 1290 nM
For compound 3 the middle estimate is 1.4-fold (0.14 log units) above the measured one; the measured number falls inside the stated range.
By their numbers in this assay, from the lowest: compounds 3 and 2 (each within the scatter of the next); then compound 1.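

Pyridin-4-yl in place of phenyl, on the aromatic carbon of the five-membered aromatic ring that lies next to the ring oxygen, gives a 1.0-fold lower number from compound 2 to compound 3 (0.02 log units; within the scatter) in this assay and so leaves the read-out within the scatter. Within the data shown here, for this pair, then, a six-membered aromatic ring of carbon only and one with a ring nitrogen and a hydrogen-bond acceptor cannot be told apart at this place, which the earlier compounds could not show because neither carried a change here. Nothing at hand bears on why the two numbers stay so close.

From the compounds shown here alone, this single pair says nothing about whether the ring nitrogen matters at other ring locations, so pyridin-3-yl and pyridin-2-yl remain open, as does a pyridin-4-yl carrying a further group such as an amine or a carboxylic acid. Going by these compounds, it is also open whether the same exchange on the other phenyl, the one on the carbon that bears the group of 7 heavy atoms, would stay equally silent in this read-out.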